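This account rests on a few compounds, and the source may have more. Where it says the series, first, only, none or still open, it means among the compounds named here.

Compound 1 `O=C(O)c1ccc(-c2cscn2)cc1O`: 70 mg/kg
Compound 2 `O=C(O)c1cc(-c2ncco2)ccc1O`: 100 mg/kg

In a functional assay on the whole organism for inhibition, with Rattus norvegicus as the target, read by paw edema (a higher number here means that more compound is needed for the effect, a lower number that less compound is needed), compound 2 gives 100 mg/kg, the highest of the two numbers shown, but its only neighbour, compound 1, lies within the scatter of it, so no order between the two can be read. Compound 3 `O=C(O)c1cc(-n2cnnc2)ccc1O` has not yet been measured. It differs from compound 2 in one place: 4H-1,2,4-triazol-4-yl in place of 1,3-oxazol-2-yl on an aromatic carbon. For the measured compounds named here, no step between measured compounds exists to size this change, so the expected step is a 1.1-fold higher number from compound 2 to compound 3 (0.04 log units; within the scatter), nothing beyond the scatter. Compound 3 is estimated at 110 mg/kg in this assay, between 55 mg/kg and 220 mg/kg.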

Compound 3, dose for half-maximal effect: > 250 mg/kg
Compound 3: only a limit was reported; the forecaster's own chance of this, stated with the estimate: 10%; at least 2.2-fold (0.35 log units) between middle value and limit.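

Exchanging one five-membered aromatic ring for another on this carbon, para to the hydroxy group and meta to the carboxy group, is not a neutral change in this assay: the swap to 4H-1,2,4-triazol-4-yl gives an at least 2.5-fold higher number from compound 2 to compound 3 (0.39 log units; beyond the scatter). This is the first step shown that lies beyond the scatter, and its true size stays unknown. The entry for compound 3 is a limit, not a number: the limit of > 250 mg/kg in this assay, at which 1 of the 3 values shown sits.

The compounds shown leave open whether the extra ring nitrogen or the attachment through nitrogen matters, and how a phenyl ring or an amine on this carbon would read.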